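This account rests on a few compounds, and the source may have more. Where it says the series, first, only, none or still open, it means among the compounds named here.

Measured in a functional assay on MCF7 cells (Homo sapiens) for antiproliferative activity, read by sulforhodamine B assay, with a stated time of 48 h (on this read-out higher numbers stand for weaker inhibition and lower numbers for stronger inhibition), so far:
Compound 1 `Cc1ccccc1OS(=O)(=O)c1ccc(N2CCN(C)C2=O)cc1` gives 5600 nM
Compound 2 `CCN1CCN(c2ccc(S(=O)(=O)Oc3cc(OC)c(OC)c(OC)c3)cc2)C1=O` gives 700 nM
Compound 3 `CCCN1CCN(c2ccc(S(=O)(=O)Oc3ccccc3C)cc2)C1=O` gives > 100000 nM as a limit

Compound 3 has no number, only a limit of the assay, namely (the limit of > 100000 nM in this assay, at which 1 of the 3 values shown sits).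

Compound 4 `CCCN1CCN(c2ccc(S(=O)(=O)Oc3cccc(C)c3)cc2)C1=O` has the same atoms joined differently, in one place: 3-methylphenyl in place of 2-methylphenyl on an oxygen puts 3-methylphenyl in place of 2-methylphenyl on an oxygen. Among the compounds with values here, no measured step changes this group alone. Within the data shown here, the only measured step, an at least 17-fold higher number from compound 1 to compound 3 (1.25 log units; beyond the scatter), is large and beyond the scatter, but it concerns a saturated chain carbon bound to an amide-type nitrogen in a ring, so it bears on the change only indirectly. It does show that compound 3 starts from a poor place. Compound 2, which differs in both the chain and the group on the oxygen, gives 700 nM and so shows that a real number is reachable in this series.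

A moderate move towards a lower number is therefore expected, though compound 4 may well stay at the limit. The estimated change is an at least 3.3-fold lower number from compound 3 to compound 4 (0.52 log units; beyond the scatter) and it remains uncertain. Compound 4 is expected at 30000 nM, with an estimated range from 6000 nM to 100000 nM.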

Compound 4, half-maximal inhibitory concentration: 86000 nM
The estimate for compound 4 lay 2.9-fold (0.46 log units) below the measured number, within the range that was stated.
By their numbers in this assay, from the lowest: compound 2; then compound 1; then compound 4. At a limit, above all of these: compound 3.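

Placing 3-methylphenyl in place of 2-methylphenyl on the oxygen bound to the sulfonyl sulfur brings this chain onto a measurable scale: in this assay compound 4 gives 86000 nM. Compound 3 has no number, only a limit of the assay: the limit of > 100000 nM in this assay, at which 1 of the 4 values shown sits. The step reads an at least 1.1-fold lower number from compound 3 to compound 4 (0.06 log units; that floor lies within the scatter), so it is only a floor; its true size cannot be read, and that floor does not establish that the change lowers the number.

On these data alone, it remains open whether the same change would lower the number with the smaller group on the ring nitrogen in compound 1. As far as these compounds go, it is also open how an unsubstituted phenyl or a chlorophenyl on the same oxygen would compare with 2-methylphenyl and 3-methylphenyl.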